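A few compounds are considered here, and "the series" means these few. Any claim that something is new, unique, unknown or untested is made for them only; others in the source may bear on it.

Measured in a functional assay on L1210 cells (Mus musculus), read by MTT assay; on this read-out higher numbers stand for weaker inhibition and lower numbers for stronger inhibition:
Compound 1 `CCC#C[C@@]1(O)[C@@H](CO)O[C@@H](n2ccc(N)nc2=O)[C@@H]1O`: 129000 nM
Compound 2 `Nc1ccn([C@@H]2O[C@H](CO)[C@](O)(C3CC3)[C@H]2O)c(=O)n1`: > 350000 nM
Compound 3 `CCC#C[C@@]1(O)[C@@H](CO)O[C@@H](n2ccc(=O)[nH]c2=O)[C@@H]1O`: 338000 nM

The entry for compound 2 is a limit and not a number. Compound 2 thus stands at the limit of > 350000 nM in this assay, at which 1 of the 3 values shown sits. The next compound to be tested is compound 4 `C#CC[C@@]1(O)[C@@H](CO)O[C@@H](n2ccc(N)nc2=O)[C@@H]1O`, which differs from compound 2 by propargyl in place of cyclopropyl on a saturated ring carbon.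

Among the compounds with values here, one measured step bears on this change: an at least 2.7-fold higher number from compound 1 to compound 2 (0.43 log units; beyond the scatter), with cyclopropyl in place of but-1-yn-1-yl on a saturated ring carbon. Compound 4 regains a triple bond outside aromatic rings, though in a different group. Given an at least 2.7-fold higher number from compound 1 to compound 2 (0.43 log units; beyond the scatter), a modest move towards a lower number is therefore expected, of about that size, although that step is itself open-ended and compound 4 may also end at the limit. The expected step is an at least 2.0-fold lower number from compound 2 to compound 4 (0.31 log units; beyond the scatter). Compound 4 is estimated at 170000 nM, with an expected range from 40000 nM to 350000 nM.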

Compound 4, half-maximal inhibitory concentration: > 350000 nM
Compound 4 was reported as a limit; the forecaster's own chance of this, stated with the estimate: 30%; middle value at least 2.0-fold (0.31 log units) from the limit.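

In this assay, propargyl in place of but-1-yn-1-yl gives an at least 2.7-fold higher number from compound 1 to compound 4 (0.43 log units; beyond the scatter), so a triple bond outside aromatic rings on this saturated ring carbon does not by itself keep the value of compound 1. The entry for compound 4, > 350000 nM, is a limit of the assay and not a number. The step between compound 2 and compound 4 cannot be read, as both entries are limits, and propargyl and cyclopropyl now both end at the same ceiling: the limit of > 350000 nM in this assay, at which 2 of the 4 values shown sit.

From the compounds shown here alone, how far compound 2 and compound 4 lie beyond that limit remains open. Also open, going by these compounds, is whether another group on this carbon, such as an amine or a longer chain ending in a triple bond, would match or improve on compound 1.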